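Nitro to Chloro in an Antiproliferative Series

The source may report more compounds than this note shows. Statements on the series, on what has been measured and on what is new or still open speak of the compounds shown alone.

Compound 1 `Clc1ccc(Nc2nccc(-c3ccc(Br)cc3)n2)c(Cl)c1`: 3780 nM
Compound 2 `O=[N+]([O-])c1ccc(Nc2nccc(-c3ccc(Br)cc3)n2)cc1`: 76000 nM

In a functional assay on A549 cells (Homo sapiens) for antiproliferative activity, read by MTT assay (a higher number here means a weaker inhibitor, a lower number a stronger inhibitor), compound 2 has the higher of the two numbers, at 76000 nM, and compound 1 stands at 3780 nM. The gap between these two compounds lies beyond the usual scatter. Compound 3 `Clc1ccc(Nc2nccc(-c3ccc(Br)cc3)n2)cc1` is still unmeasured. It differs from compound 2 as follows: chloro in place of nitro on an aromatic carbon. Going by the values given here, no measured pair shows this change directly. Compound 1, which also carries chloro, gives 3780 nM, so a drop beyond the scatter, toward a stronger inhibitor, is expected in this assay. The expected step is a 9.5-fold lower number from compound 2 to compound 3 (0.98 log units; beyond the scatter). Compound 3 is estimated at 8000 nM, with an expected range of 2500 nM to 28000 nM.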

Compound 3, half-maximal inhibitory concentration: 6110 nM
Compound 3: the middle estimate sits 1.3-fold (0.12 log units) above what was measured; low and high end bracket the measured number.
By their numbers in this assay, from the lowest: compounds 1 and 3 (each within the scatter of the next); then compound 2.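

In this assay chloro in place of nitro, on an aromatic carbon para to a large group, gives a 12-fold lower number from compound 2 to compound 3 (1.09 log units; beyond the scatter) as a single change, a large step that the earlier pair could not isolate. Hydrogen in place of the further chloro of compound 1 gives a 1.6-fold higher number from compound 1 to compound 3 (0.21 log units; within the scatter) and so stays within the scatter, which means that further chloro is not needed to hold this level. Nothing available here explains the step away from nitro. The compounds shown leave open whether fluoro, methoxy or an amine at this place would match chloro, and whether the gain comes from chloro itself or from the loss of nitro.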